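This account rests on a few compounds, and the source may have more. Where it says the series, first, only, none or still open, it means among the compounds named here.

Compound 1 `COc1ccc(-c2nc(/N=C(\N)N3CCOCC3)sc2-c2ccc(OC)cc2)cc1` gives, in a functional assay with Oryctolagus cuniculus as the target (on this read-out lower numbers stand for stronger inhibition and higher numbers for weaker inhibition), a reading of < 1000 nM, which is a limit of the assay and not a number.
Compound 2 `COc1ccc(-c2nc(/N=C(\N)n3ccnc3)sc2-c2ccc(OC)cc2)cc1` gives in this assay > 100 nM, again a limit.
Compound 3 `COc1ccc(-c2nc(CN)sc2-c2ccc(OC)cc2)cc1` gives in this assay > 100 nM, also a limit.

Compound 1 therefore stands only as a limit, and the two further values shown are limits as well; the evidence is the limit of < 1000 nM in this assay, at which 1 of the 3 values shown sits, and (the limit of > 100 nM in this assay, at which 2 of the 3 values shown sit). The steps a step that the limit leaves unreadable from compound 1 to compound 2, a step that the limit leaves unreadable from compound 1 to compound 3 and a step that the two limits leave unreadable from compound 2 to compound 3 are accordingly unreadable in size and direction.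

Compound 4 `COc1ccc(-c2nc(CNC(=O)N3CCOCC3)sc2-c2ccc(OC)cc2)cc1` differs from compound 1 by a group of 10 heavy atoms (6 carbon, 2 nitrogen, 2 oxygen; one six-membered non-aromatic ring with 2 hetero atoms) in place of a group of 9 heavy atoms (5 carbon, 3 nitrogen, 1 oxygen; one six-membered non-aromatic ring with 2 hetero atoms), on an aromatic carbon. The step to compound 3 bears most closely on this change, since compound 4 keeps the aminomethyl arrangement of compound 3 with a morpholinylcarbonyl added on it, and compound 3 gives only > 100 nM. From compound 1 no readable step exists, so no size can be taken from it. The estimate for compound 4 is therefore 1000 nM, between 200 nM and 5000 nM, expected as a step of a number no lower from compound 1 to compound 4 (the limit leaves the size open), with a real chance that the assay again reports only a limit.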

Compound 4, half-maximal inhibitory concentration: 660 nM
The estimate for compound 4 lay 1.5-fold (0.18 log units) above the measured number, and the stated range covers the measured number.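

Compound 4 has a true number in this assay, but compound 1, compound 2 and compound 3 stand only as limits, so none of its steps to them can be read. The compounds shown leave open how strongly each group at this place on the shared core inhibits relative to the others.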